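The source may report more compounds than this note shows. Statements on the series, on what has been measured and on what is new or still open speak of the compounds shown alone.

Measured in a functional assay on ZR-75-1 cells (Homo sapiens) for cytotoxicity, read by MTT assay, with a stated time of 72 h; a higher number here means that more compound is needed for the effect, a lower number that less compound is needed:
- Compound 1 `CCOc1c(-c2occ(C)c2C(=O)O)ccc2c(CC)cccc12` gives > 10 ug/mL, a limit of the assay and not a number.
- Compound 2 `CCOC(=O)c1c(C)coc1-c1ccc2c(CC)cccc2c1OC` gives 3.9 ug/mL.

Among the compounds with values here, compound 2 holds the only actual number so far, and that number is the sole anchor for what follows. Compound 3 `CCc1cccc2c(OC)c(-c3occ(C)c3C(=S)OC)ccc12` is the next to be read in this assay. Its change from compound 2 is a group of 4 heavy atoms (2 carbon, 1 oxygen, 1 sulfur; no ring) in place of a group of 5 heavy atoms (3 carbon, 2 oxygen; no ring), on an aromatic carbon. The swap sits on an aromatic carbon of a five-membered aromatic ring with 1 oxygen, and it removes ethoxycarbonyl. Within the data shown here, no measured step between compounds that differ in one place is available to size this change. The estimate therefore rests on compound 2 at 3.9 ug/mL alone, with no direction favoured. The expected 1.1-fold lower number from compound 2 to compound 3 (0.02 log units; within the scatter) lies within the usual scatter. Compound 3 is expected at 3.7 ug/mL, with an estimated range from 1.3 ug/mL to 10 ug/mL.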

Compound 3, concentration for half-maximal effect: 5.8 ug/mL
The estimate for compound 3 lay 1.6-fold (0.20 log units) below the measured number; measured number inside the range.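

In this assay, this position on the five-membered aromatic ring now has its first sized change: replacing ethoxycarbonyl with the group of 4 heavy atoms that carries sulfur gives a 1.5-fold higher number from compound 2 to compound 3 (0.17 log units; within the scatter). That step lies within the scatter, so compound 2 and compound 3 cannot be ordered, and this single swap shows no effect on the read-out that can be told from noise. Compound 1 remains a limit of the assay and not a number, and it differs from compound 2 in more than one place, so it cannot size this position: the limit of > 10 ug/mL in this assay, at which 1 of the 3 values shown sits.

Open, from the compounds shown here alone, is whether an amide, a nitrile or a longer chain than ethoxycarbonyl at this position would move the number beyond the scatter. One step on one cell line also leaves open whether the flat result holds for other groups here.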